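Working notes: from compound 1 to compound 4

The compounds below may be only part of what the source reports. "The series", "measured", "known", "first", "only" and "open" are said of these compounds alone.

Three compounds of the shared core have numbers in a functional assay on L1210 cells (Mus musculus), with a stated time of 12 days; a higher number here means a more potent compound, by a factor of ten per unit of this negative logarithm, a lower number a less potent compound. Compound 1 `CC1=C(N2CC2)C(=O)C(CC(C)OC(N)=O)=C(N2CC2)C1=O` gives 5.79. Compound 2 `CCC1=C(N2CC2)C(=O)C(CCOC(N)=O)=C(N2CC2)C1=O` gives 5.48, and compound 3 `CC(C)C1=C(N2CC2)C(=O)C=C(N2CC2)C1=O` gives 5.37. Compound 1 stands highest of the three, and its gaps to compound 2 and to compound 3 both lie beyond the usual scatter, so among these three it is the most potent as measured. Among the measured compounds shown here, no pair of the measured compounds differs in only one place, so no single step can be read directly from them, and the values are taken only as they stand.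

Compound 4 `CC1=C(N2CC2)C(=O)C(Cc2ccccc2)=C(N2CC2)C1=O` has not yet been measured. Against compound 1 the change is a group of 6 heavy atoms (6 carbon; one six-membered aromatic ring of carbon only) in place of a group of 6 heavy atoms (3 carbon, 1 nitrogen, 2 oxygen; no ring), on a saturated chain carbon bound to a double-bonded ring carbon. The group that leaves is the side chain that sets compound 1 apart from compound 3, which carries no chain at that place and gives 5.37, the lowest number of the set. Compound 4 also loses that group, though phenyl enters in its stead. On that ground the expected step is a number 0.39 log units lower from compound 1 to compound 4 (beyond the scatter), a loss beyond the usual scatter. For compound 4 the estimate in this assay is 5.4, with a range from 4.9 to 5.9.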

Compound 4, logarithm of the reciprocal of the active concentration, log(1/C): 4.69
Beside the measured number, compound 4's estimate is 0.71 log units above it; measured number outside the range, below it.
By their numbers in this assay, from the lowest: compound 4; then compounds 3 and 2 (each within the scatter of the next); then compound 1.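

In this assay, among the compounds shown here, the exchange on a saturated chain carbon bound to a double-bonded ring carbon gives the first single change that can be read: a number 1.10 log units lower from compound 1 to compound 4 (beyond the scatter), a large step. The heavy-atom count stays at 6 across the change, while the 1 hydrogen-bond donor and 2 hydrogen-bond acceptors of the group that leaves fall to 0 with phenyl, so this place is shown to be sensitive to what it carries even at an equal count of heavy atoms. No measurement among the data bears on this result, and the step stands without an established cause.

With a single pair differing in one place, the step cannot be divided between the loss of the leaving group and the entry of phenyl. A simple alkyl chain of 6 carbons, an amine or a carboxylic acid at this place on the core of compound 1 would help separate those two readings, and would show whether the drop belongs to the aromatic ring or to the absence of nitrogen and oxygen.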